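Carboxy to carboxymethyl on compound 2: expected permeability

A few compounds are considered here, and "the series" means these few. Any claim that something is new, unique, unknown or untested is made for them only; others in the source may bear on it.

Working notes on the series. Among the measured compounds shown here, in a physicochemical assay for permeability, using PAMPA, with a stated time of 4 h, at pH 7.4, tested at 50 uM (on this read-out lower numbers stand for lower permeability and higher numbers for higher permeability), compound 2 `Cc1c(Cl)cccc1CCCCOc1ccc(C#Cc2cccc3c(CC(=O)O)c(C)n(CCCCC(=O)O)c23)cc1` gives 1 10^-6 cm/s, the only numerical reading obtained so far. Compound 1 `O=C(O)CCCc1cn(CC(=O)O)c2c(/C=C/c3ccc(OCCCCc4c(F)ccc(F)c4F)cc3)cccc12` returns only a limit in this assay, < 0.05 10^-6 cm/s. That reading sits at the limit of < 0.05 10^-6 cm/s in this assay, at which 1 of the 2 values shown sits, so it cannot be compared with compound 2 as a number.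

Compound 3 `Cc1c(Cl)cccc1CCCCOc1ccc(C#Cc2cccc3c(CCC(=O)O)c(C)n(CCCCC(=O)O)c23)cc1` is not yet measured in this assay. It differs from compound 2 by carboxymethyl in place of carboxy on a saturated chain carbon bound to an aromatic carbon. For the measured compounds named here, no measured pair in the set shows a change of this kind, so the step from compound 2 to compound 3 in this assay is expected to fall within the usual scatter, with no clear direction. On that basis compound 3 is expected to give 1.2 10^-6 cm/s in this assay, with a range of 0.5 10^-6 cm/s to 3 10^-6 cm/s. The step this estimate implies is a 1.2-fold higher number from compound 2 to compound 3 (0.08 log units; within the scatter).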

Compound 3, apparent permeability: 4.6 10^-6 cm/s
The estimate for compound 3 lay 3.8-fold (0.58 log units) below the measured number, outside the stated range (above it).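

Carboxymethyl in place of carboxy on a saturated chain carbon bound to an aromatic carbon gives a 4.6-fold higher number from compound 2 to compound 3 (0.66 log units; beyond the scatter) in this assay, so the read-out responds to a change at this position, which the earlier compounds could not show. The two groups have the same hydrogen-bond donor and acceptor counts and no net charge, and the entering group has one more carbon. No measurement in the set bears on the cause of this step.

This single pair leaves open whether a longer chain ending in a carboxylic acid at this place would extend the step or reverse it. It also leaves open how a primary amide or a tetrazole in place of the carboxylic acid at this place would read in this assay.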